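From 4-Bromophenyl to 3-Methylphenyl: Expected Cytotoxicity

The source may report more compounds than this note shows. Statements on the series, on what has been measured and on what is new or still open speak of the compounds shown alone.

Compound 1 `C/C(=C\CC/C(C)=C/CC[C@@H]1[C@@]2(C)CCC(=O)C(C)(C)[C@H]2CC[C@@]1(C)O)CC/C=C(\C)C(=O)OCc1cn(-c2ccc(Br)cc2)nn1` — > 150000 nM
Compound 2 `C/C(=C\CC/C(C)=C/CC[C@@H]1[C@@]2(C)CCC(=O)C(C)(C)[C@H]2CC[C@@]1(C)O)CC/C=C(\C)C(=O)OCc1cn([C@@H]2C[C@@H](n3cc(C)c(=O)[nH]c3=O)O[C@H]2CO)nn1` — 115000 nM
Compound 3 `C/C(=C\CC/C(C)=C/CC[C@@H]1[C@@]2(C)CCC(=O)C(C)(C)[C@H]2CC[C@@]1(C)O)CC/C=C(\C)C(=O)O` — > 150000 nM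

All three were tested in an ADME assay on L132 cells (Homo sapiens) for cytotoxicity, read by MTT assay, with a stated time of 48 h; a higher number here means a weaker inhibitor, a lower number a stronger inhibitor. Compound 1 gives only a limit, > 150000 nM, not a number. Compound 3 also ends at a limit, > 150000 nM. Compound 2 gives a number, 115000 nM. Compound 1 therefore stands at the limit of > 150000 nM in this assay, at which 2 of the 3 values shown sit, and it cannot be ranked against the others. Compound 4 `C/C(=C\CC/C(C)=C/CC[C@@H]1[C@@]2(C)CCC(=O)C(C)(C)[C@H]2CC[C@@]1(C)O)CC/C=C(\C)C(=O)OCc1cn(-c2cccc(C)c2)nn1` differs from compound 1 in a single place: 3-methylphenyl in place of 4-bromophenyl on an aromatic nitrogen. For the measured compounds named here, no measured pair shows what such an exchange does in this assay, so there is no basis for expecting a shift beyond the scatter. The expected step of a number no higher from compound 1 to compound 4 (the limit leaves the size open) is accordingly close to none. Compound 4 is expected to give about 150000 nM, within 80000 nM to 300000 nM, most likely again as a limit.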

Compound 4, half-maximal inhibitory concentration: > 150000 nM
Compound 4: only a limit was reported; the forecaster's own chance of this, stated with the estimate: 70%; the middle value lies on the limit itself.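

Compound 1 and compound 4 both end in a limit rather than a number, and no step can be read between them. As far as these compounds go, whether 3-methylphenyl in place of 4-bromophenyl changes cytotoxicity at all, and how these two compounds rank, stays open.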